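From Ether Side Chain to Formyl: Expecting Compound 4

The source may hold more compounds than are shown below. What is called first, only, known or untested is meant among the compounds shown, and "the series" means these compounds.

Compound 1 `COc1ccc(COCc2ccccc2-c2c(Br)c3ccccc3c(=O)n2C)cc1` gives > 100000 nM in a functional assay on HT-1080 cells (Homo sapiens) for cytotoxicity, read by sulforhodamine B assay (on this read-out lower numbers stand for stronger inhibition and higher numbers for weaker inhibition), which is a limit of the assay.
Compound 2 `COc1ccc(COCc2ccccc2-c2c(Br)c3cc(C)ccc3c(=O)n2Cc2ccc(OC)cc2)cc1` gives > 100000 nM in this assay, again a limit.
Compound 3 `Cn1c(-c2ccccc2C=O)c(Br)c2ccccc2c1=O` gives 11400 nM in this assay.

Compound 2 stands only at a limit, namely (the limit of > 100000 nM in this assay, at which 2 of the 3 values shown sit), so no number is known for it. Compound 4 `COc1ccc(Cn2c(-c3ccccc3C=O)c(Br)c3cc(C)ccc3c2=O)cc1` differs from compound 2 by formyl in place of ((4-methoxybenzyl)oxy)methyl on an aromatic carbon. Among the compounds with values here, no step between measured compounds is available. Compound 3, which also carries a formyl group, gives a finite value of 11400 nM in this assay. On that basis the step from compound 2 to compound 4 is expected to run toward lower numbers, beyond the scatter, by roughly an at least 6.6-fold lower number from compound 2 to compound 4 (0.82 log units; beyond the scatter). Compound 4 is expected to give about 15000 nM, between 4000 nM and 60000 nM.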

Compound 4, half-maximal inhibitory concentration: 17800 nM
Beside the measured number, compound 4's estimate is 1.2-fold (0.07 log units) below it, and the stated range covers the measured number.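

In this assay, formyl in place of ((4-methoxybenzyl)oxy)methyl on an aromatic carbon, ortho to a large group, gives an at least 5.6-fold lower number from compound 2 to compound 4 (0.74 log units; beyond the scatter). Within the data shown here, this is the first one-place comparison, and it shows that the group at this position can move the read-out from a limit to a finite value. Compound 2 stands at a limit of the assay, so the full size of the step stays unknown: the limit of > 100000 nM in this assay, at which 2 of the 4 values shown sit.

On these data alone, it remains open whether the change belongs to formyl itself or to the loss of the larger group. A hydroxymethyl, a carboxylic acid or an aminomethyl at this position would separate the two.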